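Swapping cyclohexyl for phenyl on the purine amine

This account rests on a few compounds, and the source may have more. Where it says the series, first, only, none or still open, it means among the compounds named here.

The series is judged in a functional assay on NCI-H460 cells (Homo sapiens) for antiproliferative activity, read by CCK-8 assay, with a stated time of 72 h, tested at 8 uM; a lower number here means a weaker effect, a higher number a stronger effect of the compound at the concentration tested. Compound 1 `CC1CCN(c2nc(Cl)nc3c2ncn3Cc2ccc(/C=C/C(=O)Nc3ccccc3N)cc2)CC1` gives 10.8%, compound 2 `Nc1ccccc1NC(=O)c1ccc(Cn2cnc3c(Nc4ccccc4)nc(Cl)nc32)cc1` gives 77.8%, and compound 3 `Nc1ccccc1NC(=O)/C=C/c1ccc(Cn2cnc3c(NC4CCCCC4)nc(Cl)nc32)cc1` gives 24.9%. Compound 3 thus stands second of the three, a number a number 14.1 percentage points higher from compound 1 to compound 3 (beyond the scatter) apart from compound 1 and well short of compound 2.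

Compound 4 `Nc1ccccc1NC(=O)/C=C/c1ccc(Cn2cnc3c(Nc4ccccc4)nc(Cl)nc32)cc1` is not yet measured. It differs from compound 3 by phenyl in place of cyclohexyl on a nitrogen on an aromatic ring.

Within the data shown here, only one measured step bears on this position: the change from compound 1 to compound 3, a modest rise of a number 14.1 percentage points higher from compound 1 to compound 3 (beyond the scatter), which shows that the group on this nitrogen matters. Among the measured compounds shown here, no measured step isolates phenyl against cyclohexyl here; compound 2 carries the anilino group and gives 77.8%, but it differs from compound 3 in more than one place, so its value is only a hint. He therefore expects compound 4 to rise above compound 3 by an estimated a number 25.1 percentage points higher from compound 3 to compound 4 (beyond the scatter), with wide uncertainty, and estimates compound 4 at 50%, between 25% and 80%.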

Compound 4, a percentage reported as inhibition, at one concentration (the size of the read-out at that concentration, not a potency): 28.7%
The estimate for compound 4 lay 21.3 percentage points above the measured number, within the range that was stated.
By their numbers in this assay, from the lowest: compound 1; then compounds 3 and 4 (each within the scatter of the next); then compound 2.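

A reading of a number 3.8 percentage points higher from compound 3 to compound 4 (within the scatter) in this assay shows that phenyl and cyclohexyl on this nitrogen cannot be told apart here, so the anilino group alone does not carry compound 4 to the level of compound 2. Anilino still differs from 4-methylpiperidin-1-yl, with a number 17.9 percentage points higher from compound 1 to compound 4 (beyond the scatter) as the step between those two compounds. The large step lies in the other place, where a number 49.1 percentage points lower from compound 2 to compound 4 (beyond the scatter) goes with 2-((2-aminophenyl)carbamoyl)ethenyl in place of (2-aminophenyl)carbamoyl. No evidence accounts for these steps. The compounds shown leave open whether cyclohexylamino would match anilino when joined to (2-aminophenyl)carbamoyl, and whether a benzyl group on this nitrogen would depart from phenyl and cyclohexyl.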